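The source may hold more compounds than are shown below. What is called first, only, known or untested is meant among the compounds shown, and "the series" means these compounds.

Among the compounds with values here, in a functional assay on KB cells (Homo sapiens) for cytotoxicity (a higher number here means a weaker inhibitor, a lower number a stronger inhibitor), compound 1 `COc1ccc2c(c1)C(=O)C=CC2=O` gives 33900 nM and compound 2 `O=C1C=CC(=O)c2cc(Oc3ccco3)ccc21` gives 15800 nM, the lower of the two numbers measured so far. Compound 3 `CC(=O)Oc1ccc2c(c1)C(=O)C=CC2=O` is still unmeasured. It differs from compound 2 as follows: acetyl in place of furan-2-yl on an oxygen on an aromatic ring. Within the data shown here, only one measured step bears on this change: a 2.1-fold lower number from compound 1 to compound 2 (0.33 log units; beyond the scatter), a modest step at the same kind of oxygen. Among the measured compounds shown here, no measurement with acetyl on that oxygen exists yet, so that step is the only guide to size. In this assay, a step no larger than that one is therefore expected, leaning towards a higher number and possibly not beyond the scatter. The expected change is a 1.4-fold higher number from compound 2 to compound 3 (0.14 log units; within the scatter). Compound 3 is estimated at 22000 nM, with an expected range of 8000 nM to 50000 nM.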

Compound 3, half-maximal inhibitory concentration: 22100 nM
Compound 3: the middle estimate sits 1.0-fold (0.00 log units) below what was measured, within the range that was stated.
By their numbers in this assay, from the lowest: compounds 2, 3 and 1 (each within the scatter of the next, the first and the last beyond it).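

In this assay, acetyl on this oxygen gives no step beyond the scatter from either neighbouring group: a 1.4-fold higher number from compound 2 to compound 3 (0.15 log units; within the scatter) and a 1.5-fold lower number from compound 1 to compound 3 (0.19 log units; within the scatter). Compound 3 therefore cannot be separated from compound 1 or compound 2, although those two remain apart, so among the three groups on this oxygen only the change between methyl and furan-2-yl is resolved. The data hold nothing that accounts for these steps.

On these data alone, what a free hydroxyl on the same position, or a longer acyl chain such as butanoyl in place of acetyl, would give stays open. Also open, as far as these compounds go, is whether an amine or a carboxylic acid carried on this oxygen would move the number further than furan-2-yl does.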